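The compounds below may be only part of what the source reports. "The series", "measured", "known", "first", "only" and "open" are said of these compounds alone.

This account follows the step from compound 2 `Nc1c(C(=O)O)sc2nc(-c3cccs3)cc(-c3ccccc3)c12` to compound 3 `CCC[S+]([O-])c1sc2nc(-c3cccs3)cc(-c3ccccc3)c2c1N` in an assay for inhibition of 15-hydroxyprostaglandin dehydrogenase [NAD(+)] (Homo sapiens), read by fluorescence, with a stated time of 15 min, in the presence of a further agent that is not named here; a higher number here means a weaker inhibitor, a lower number a stronger inhibitor. Compound 2 has given no number in this assay but only a limit, > 7500 nM. That is where compound 2 stands: at the limit of > 7500 nM in this assay, at which 1 of the 2 values shown sits. The other measured compound, compound 1 `CCC[S+]([O-])c1sc2nc(-c3cccs3)cc(C(=O)O)c2c1N`, is known in this assay with 71 nM, a number rather than a limit. Compound 3 arises from compound 2 by a single change: a group of 5 heavy atoms (3 carbon, 1 oxygen, 1 sulfur; no ring) in place of a group of 3 heavy atoms (1 carbon, 2 oxygen; no ring), on an aromatic carbon. The rest of the molecule is kept. The group of 5 heavy atoms that enters is the same group that compound 1 carries on its core, while compound 2 lacks it. Among the compounds with values here, no step between two measured compounds that differ in one place is available, so the size of the step cannot be read from a precedent and has to be expected. The expected step is an at least 12-fold lower number from compound 2 to compound 3 (1.09 log units; beyond the scatter), toward stronger inhibition, beyond the usual scatter. This expectation rests on compound 1, which gives 71 nM with the entering group in place. Compound 2, which lacks that group, stands only at its limit, as said above. Compound 3 is therefore estimated at 600 nM, within 80 nM to 5000 nM.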

Compound 3, half-maximal inhibitory concentration: 2.1 nM
Compound 3: the middle estimate sits 290-fold (2.46 log units) above what was measured, outside the stated range (below it).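

In this assay, putting the group of 5 heavy atoms in place of carboxy on the aromatic carbon next to the ring sulfur gives an at least 3500-fold lower number from compound 2 to compound 3 (3.55 log units; beyond the scatter), so this position responds very strongly to the change when phenyl is present on the core. Compound 2 is known only by a limit, so the full size of that step stays undetermined: the limit of > 7500 nM in this assay, at which 1 of the 3 values shown sits.

The second comparison adds what compound 1 alone could not show, since phenyl in place of carboxy on an aromatic carbon gives a 34-fold lower number from compound 1 to compound 3 (1.53 log units; beyond the scatter), which means that, with the group of 5 heavy atoms in place, strong inhibition in this assay does not depend on a carboxy group anywhere on the core.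

The compounds shown leave open how much of the gain belongs to the chain of the entering group and how much to its sulfur and oxygen, which a shorter ethyl chain, a longer butyl chain or a simple methyl group at the same carbon would help to separate. They also leave open whether a phenyl with a substituent, or a small amine in its place, would keep this level of inhibition.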